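A few compounds are considered here, and "the series" means these few. Any claim that something is new, unique, unknown or untested is made for them only; others in the source may bear on it.

Compound 1 `Cc1c(-c2ccc(-c3ccccc3F)cc2)nc2ccc(F)cc2c1C(F)F` is the point of departure. In a functional assay on MOLM-13 cells (Homo sapiens) for antiproliferative activity (a lower number here means a stronger inhibitor, a higher number a weaker inhibitor), compound 1 reaches only a limit, > 3000 nM. Compound 2 `Cc1c(-c2ccc(-c3ccccc3F)cc2)nc2ccc(F)cc2c1C(=O)NC#N` likewise shows only a limit, > 3000 nM. Compound 3 `Cc1c(-c2ccc(-c3ccccc3F)cc2)nc2ccc(F)cc2c1C(=O)NO` gives 23 nM in this assay. Two values sit at the limit of > 3000 nM in this assay, at which 2 of the 3 values shown sit. The step of an at least 130-fold lower number from compound 1 to compound 3 (2.11 log units; beyond the scatter) is large; the step that the two limits leave unreadable from compound 1 to compound 2 cannot be sized; the step of an at least 130-fold lower number from compound 2 to compound 3 (2.11 log units; beyond the scatter) is again large. Compound 4 `CCONC(=O)c1c(C)c(-c2ccc(-c3ccccc3F)cc2)nc2ccc(F)cc12` differs from compound 1 by ethoxycarbamoyl in place of difluoromethyl on an aromatic carbon. Of the two measured replacements at this carbon, only the hydroxycarbamoyl of compound 3 produced a strong value, while the cyanocarbamoyl of compound 2 did not. The expected step of an at least 2.0-fold lower number from compound 1 to compound 4 (0.30 log units; that floor lies within the scatter) is therefore modest, in the direction of lower numbers. The estimate for compound 4 in this assay is 1500 nM, between 300 nM and 6000 nM.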

Compound 4, half-maximal inhibitory concentration: 33 nM
The estimate for compound 4 lay 45-fold (1.66 log units) above the measured number; measured number below the stated range.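

In this assay, the step of a 1.4-fold higher number from compound 3 to compound 4 (0.16 log units; within the scatter) shows that the hydrogen on the oxygen of the hydroxycarbamoyl is not required for a strong value at this aromatic carbon. The ethoxycarbamoyl gives an at least 90-fold lower number from compound 1 to compound 4 (1.95 log units; beyond the scatter), and on the amide-type nitrogen, ethoxy gives an at least 90-fold lower number from compound 2 to compound 4 (1.95 log units; beyond the scatter), so a strong value here is not confined to compound 3. Compound 1 and compound 2 each stand at a limit, not a number: the limit of > 3000 nM in this assay, at which 2 of the 4 values shown sit.

Going by these compounds, whether a longer chain on the oxygen, such as butoxy, would keep such a value stays open. So does the value of a carboxylic acid at this carbon.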